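The source may report more compounds than this note shows. Statements on the series, on what has been measured and on what is new or still open speak of the compounds shown alone.

Working notes on the series. In an assay on isolated protein (strain Charles River) for antagonist activity at histamine H2 receptor (Rattus norvegicus) (a higher number here means that more compound is needed for the effect, a lower number that less compound is needed), compound 1 `CC(C)Cc1ccc2ccc(=O)n(CCN(C)C)c2n1` gives 0.16 ug/mL, compound 2 `Cc1nc2c(ccc(=O)n2CCN(C)C)c(C)c1C` gives 12.5 ug/mL, and compound 3 `Cc1cc(C)c2ccc(=O)n(CCN)c2n1` gives 33.8 ug/mL. Compound 3 therefore stands at the highest of the three numbers; the gap to compound 2 is beyond the scatter, and the gap to compound 1 is much wider still. Among the compounds with values here, no pair among the measured compounds differs in a single place, so no single-change step is available as a guide.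

Compound 4 `Cc1cc(C)c2ccc(=O)n(CCN3CCCCC3)c2n1` is the next entry: the change from compound 3 is piperidin-1-yl in place of amino on a saturated chain carbon, two bonds along the chain from an aromatic nitrogen. Within the data shown here, the only pointer is that compound 2 and compound 1, whose chain nitrogen carries no hydrogen-bond donor, give lower numbers than compound 3 in this assay, though each differs from compound 3 in more than one place. A downward step is expected, of modest size, a 4.2-fold lower number from compound 3 to compound 4 (0.63 log units; beyond the scatter), in this assay. Compound 4 is accordingly estimated at 8 ug/mL, with a plausible range of 2 ug/mL to 30 ug/mL.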

Compound 4, half-maximal effective concentration: 3.05 ug/mL
Beside the measured number, compound 4's estimate is 2.6-fold (0.42 log units) above it, within the range that was stated.
By their numbers in this assay, from the lowest: compound 1; then compound 4; then compound 2; then compound 3.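

The step gives the series its first single-change reading: on a saturated chain carbon, two bonds along the chain from an aromatic nitrogen, piperidin-1-yl in place of amino brings an 11-fold lower number from compound 3 to compound 4 (1.04 log units; beyond the scatter) in this assay and so counts as a large change. Within the data shown here, with the core of compound 3 held constant, the number in this position therefore follows the group at the chain end, a link the earlier compounds could only hint at across several differences. The change both removes the hydrogen-bond donor of amino and adds a six-membered non-aromatic ring, and no available evidence bears on the fall or tells these two differences apart.

From the compounds shown here alone, it remains open whether pyrrolidin-1-yl or morpholin-4-yl at the chain end would give a number nearer that of compound 4 or that of compound 3. Also open, going by these compounds, is whether a longer chain carrying piperidin-1-yl would keep the lower number.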